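Methyl for Isopropyl on a Weakly Active Core

A few compounds are considered here, and "the series" means these few. Any claim that something is new, unique, unknown or untested is made for them only; others in the source may bear on it.

Compound 1 `CC(C)c1nccc2nn(-c3ccccc3)cc12`: > 100000 nM
Compound 2 `CCCCc1cc2nn(-c3ccccc3)cc2c(C(C)C)n1`: 12900 nM
Compound 3 `c1ccc(-c2cc3nn(-c4ccccc4)cc3cn2)cc1`: 3400 nM

In a functional assay on K562 cells (Homo sapiens) for inhibition, read by fluorescence, with a stated time of 72 h (on this read-out lower numbers stand for stronger inhibition of growth and higher numbers for weaker inhibition of growth), compound 1 gives > 100000 nM, which is a limit of the assay rather than a number, as shown by the limit of > 100000 nM in this assay, at which 1 of the 3 values shown sits. Compound 2 gives 12900 nM and compound 3 gives 3400 nM in this assay. Within the data shown here, the only measured step, an at least 7.7-fold lower number from compound 1 to compound 2 (0.88 log units; beyond the scatter), concerns a different change and does not bear on the one considered here. Compound 4 `Cc1nccc2nn(-c3ccccc3)cc12` differs from compound 1 by methyl in place of isopropyl on an aromatic carbon. Among the measured compounds shown here, no measured step covers this change, so compound 1 offers the only anchor. Compound 4 is therefore expected to remain near the limit, at about 100000 nM (range 30000 nM to 300000 nM). The expected step is a number no higher from compound 1 to compound 4 (the limit leaves the size open), which is no change beyond the scatter.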

Compound 4, concentration for 50% growth inhibition: > 100000 nM
Compound 4: only a limit was reported (the forecaster's own chance of this, stated with the estimate: 75%); the middle value sits exactly at the limit.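

Compound 1 and compound 4 are both reported only as limits of the assay, so no step between them can be read: the limit of > 100000 nM in this assay, at which 2 of the 4 values shown sit.

The compounds shown leave open whether methyl and isopropyl differ at all in their effect on growth on the shared core.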